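This account rests on a few compounds, and the source may have more. Where it says the series, first, only, none or still open, it means among the compounds named here.

In a functional assay on cells for antagonist activity at Gonadotropin-releasing hormone receptor (Homo sapiens), read by FLIPR and calcium flux, with a stated time of 15 min (on this read-out higher numbers stand for weaker inhibition and lower numbers for stronger inhibition), compound 2 `C#CCN1CCN(c2cccc3[nH]c(-c4ccc(C(C)(C)C)cc4)nc23)CC1` gives 395 nM. Among the three compounds measured in this assay, compound 2 shows the highest number; the nearest of the others is compound 3 `COc1cc(OC)c(NC(=O)c2ccc(Cc3cc4c(cc3C)C(C)(C)CCC4(C)C)o2)c(OC)c1`, which gives 19 nM, and the furthest is compound 1 `CC(C)(C)c1ccc(-c2nc3c(N4CCN(Cc5cccc6nccnc56)CC4)cccc3[nH]2)cc1`, which gives 12.2 nM, so compound 2 stands apart from both by more than the scatter.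

Compound 4 `CC(C)(C)c1ccc(-c2nc3c(N4CCN(Cc5cn(-c6ccc(F)cc6)nn5)CC4)cccc3[nH]2)cc1` has not yet been measured. It differs from compound 2 in one place: 1-(4-fluorophenyl)-1H-1,2,3-triazol-4-yl in place of ethynyl on a saturated chain carbon bound to an amine nitrogen in a ring. Within the data shown here, the one measured step that bears on this change is the one from compound 1 to compound 2, in which the quinoxalin-5-yl group on the same saturated chain carbon was replaced by ethynyl and the number rose sharply: a 32-fold higher number from compound 1 to compound 2 (1.51 log units; beyond the scatter). Compound 4 moves in the opposite direction, putting an aromatic group back in the place where compound 2 holds only ethynyl. Among the measured compounds shown here, the entering group is not the one that compound 1 carries, so a full return to the number of compound 1 cannot simply be assumed, but a step of comparable direction is expected.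

Compound 4 is therefore expected to give a number well below that of compound 2 in this assay, with an estimated step of a 13-fold lower number from compound 2 to compound 4 (1.12 log units; beyond the scatter). The estimate for compound 4 is 30 nM, with a range from 8 nM to 120 nM.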

Compound 4, inhibition constant: 410 nM
Beside the measured number, compound 4's estimate is 14-fold (1.14 log units) below it, and the stated range ends below it.
By their numbers in this assay, from the lowest: compounds 1 and 3 (each within the scatter of the next); then compounds 2 and 4 (each within the scatter of the next).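

In this assay, an aromatic group on a saturated chain carbon bound to an amine nitrogen in a ring is not enough to bring the number down to that of compound 1: the step of a 1.0-fold higher number from compound 2 to compound 4 (0.02 log units; within the scatter) lies within the scatter, even though 1-(4-fluorophenyl)-1H-1,2,3-triazol-4-yl is far larger than ethynyl and brings aromatic rings and hydrogen-bond acceptors. The replacement of quinoxalin-5-yl by this triazolyl group gives a 34-fold higher number from compound 1 to compound 4 (1.53 log units; beyond the scatter), a large step comparable in size to the one to ethynyl, so among these three compounds only the quinoxalin-5-yl group goes with the low number. Among these compounds, the change therefore separates the presence of an aromatic group from the identity of that group, which the single earlier step could not do. No measurement shown here offers an explanation for this difference between the groups.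

As far as these compounds go, it remains open whether the low number of compound 1 is specific to quinoxalin-5-yl or would also be seen with a related bicyclic group such as quinolin-8-yl or naphthalen-1-yl. From the compounds shown here alone, it is equally open whether a simple phenyl or a 1-phenyl-1H-1,2,3-triazol-4-yl without fluorine would behave like compound 4.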